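The source may hold more compounds than are shown below. What is called first, only, known or untested is meant among the compounds shown, and "the series" means these compounds.

The study sets compound 1 `COc1cc(-c2cc(-c3cc(C(C)C)c(O)cc3C)[nH]c(=O)c2C#N)cc(OC)c1OC` beside compound 2 `Cc1cc(O)c(C(C)C)cc1-c1cc(-c2cccs2)c(C#N)c(=O)[nH]1`. In a functional assay for inhibition, tested at 20 ug/mL (a higher number here means a stronger effect of the compound at the concentration tested, a lower number a weaker effect), compound 1 gives 35%. In this assay compound 2 gives 26%, a number that differs from that of compound 1 by an amount within the usual scatter, so the two cannot be ordered. Compound 3 `Cc1cc(O)c(C(C)C)cc1-c1cc(-c2ccco2)c(C#N)c(=O)[nH]1` has not yet been measured; it carries furan-2-yl in place of thiophen-2-yl on an aromatic carbon. Going by the values given here, no step between measured compounds is available to rest an expectation on, so the step of no change at the digits printed from compound 2 to compound 3 (within the scatter) is expected to be none beyond the scatter. For compound 3 the estimate in this assay is 26%, within a range from 10% to 42%.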

Compound 3, a percentage reported as inhibition, at one concentration (the size of the read-out at that concentration, not a potency): 26%
Beside the measured number, compound 3's estimate shows no gap at the digits printed; low and high end bracket the measured number.
By their numbers in this assay, from the lowest: compounds 2, 3 and 1 (each within the scatter of the next).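

At the aromatic carbon opposite the ring nitrogen and ortho to a cyano group, furan-2-yl in place of thiophen-2-yl gives, in this assay, no change at the digits printed from compound 2 to compound 3 (within the scatter). Going by these compounds alone, this is the first single-place step available, and it shows that this position does not distinguish between these two five-membered aromatic rings, which differ in a sulfur or an oxygen as the hetero atom, at the concentration tested. Nothing at hand offers a reason for this result.

What the compounds shown leave open is how an amine or a carboxylic acid at this position would read in this assay. They also leave open whether any change here would move the read-out beyond the scatter.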